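The compounds below may be only part of what the source reports. "The series", "measured", "known", "first", "only" and "open" are said of these compounds alone.

Working notes on the series. In a functional assay on K562 cells (Homo sapiens) for cytotoxicity, read by MTT assay (a higher number here means that more compound is tolerated, a lower number that less compound is tolerated), compound 1 `C/C(=C/CC[C@@H](C)CC(=O)O)CC/C=C(/C)CCCc1ccoc1` gives > 100 ug/mL, which is a limit of the assay and not a number; this is the limit of > 100 ug/mL in this assay, at which 1 of the 3 values shown sits. Compound 2 `COC(=O)C(C)(O)[C@](O)(C[C@H](C)CCC/C(C)=C/CC/C(C)=C/CCc1ccoc1)C(=O)OC` gives 20 ug/mL and compound 3 `COC(=O)C(C)(O)[C@](O)(C[C@H](C)CC/C=C(/C)CC/C=C(/C)CCCc1ccoc1)C(=O)OC` gives 34 ug/mL, two values within the usual scatter of each other. The next compound is compound 4 `CC1=C(O)/C(=C/[C@H](C)CC/C=C(/C)CC/C=C(/C)CCCc2ccoc2)OC1=O`, and the change is a group of 9 heavy atoms (6 carbon, 3 oxygen; one five-membered non-aromatic ring with 1 hetero atom) in place of a group of 4 heavy atoms (2 carbon, 2 oxygen; no ring), on a saturated chain carbon bound to two saturated chain carbons: carboxymethyl leaves, and a group with one five-membered non-aromatic ring enters on a saturated chain carbon bound to two saturated chain carbons. Among the measured compounds shown here, no step between measured compounds is available, so the size of the change rests on the values alone. The chain of compound 1 recurs in compound 3, which gives 34 ug/mL without carboxymethyl in that place, so a measured number rather than a limit is expected for compound 4. The expected step of an at least 5.0-fold lower number from compound 1 to compound 4 (0.69 log units; beyond the scatter) in this assay points towards less compound tolerated and beyond the scatter. The estimate for compound 4 is 20 ug/mL, with an expected range from 6 ug/mL to 60 ug/mL.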

Compound 4, concentration lethal to 50% of the cells: 62 ug/mL
Beside the measured number, compound 4's estimate is 3.1-fold (0.49 log units) below it, outside the stated range (above it).
By their numbers in this assay, from the lowest: compounds 2, 3 and 4 (each within the scatter of the next, the first and the last beyond it). At a limit, above all of these: compound 1.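

In this assay compound 1 gives > 100 ug/mL, which is a limit of the assay and not a number. With a group with one five-membered non-aromatic ring in place of carboxymethyl, on a saturated chain carbon bound to two saturated chain carbons, this chain now has a measured number, and the change reads as an at least 1.6-fold lower number from compound 1 to compound 4 (0.20 log units; that floor lies within the scatter). The true size of the step stays unread because compound 1 sits at the limit of the assay: the limit of > 100 ug/mL in this assay, at which 1 of the 4 values shown sits.

As far as these compounds go, whether the ring that enters or the loss of carboxymethyl carries the step remains open. A compound with an amine or a primary amide on the same carbon, read in this assay, would bear on that question.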